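The compounds below may be only part of what the source reports. "The series", "measured", "known", "first", "only" and "open" are said of these compounds alone.

Compound 1 `CCCCCc1cn(C(c2ccccc2)c2cc3cc(Br)ccc3nc2OC)nn1` gives 10.5% in an ADME assay on SK-OV-3 cells (Homo sapiens) for cytotoxicity, read by sulforhodamine B assay, with a stated time of 48 h, tested at 10 uM; on this read-out lower numbers stand for less inhibition and higher numbers for more inhibition at the one concentration tested (going by the name of the read-out).
Compound 2 `COc1nc2ccc(Br)cc2cc1C(c1ccccc1)n1cc(CO)nn1` gives 3.23% in this assay.

On these two numbers compound 2 and compound 1 sit within the scatter of each other, so neither stands apart. Compound 3 `COc1nc2ccc(Br)cc2cc1C(c1ccccc1)n1cc(CCCCCO)nn1` differs from compound 2 by 4-hydroxybutyl in place of hydroxy on a saturated chain carbon bound to an aromatic carbon. Among the compounds with values here, the only measured step touching this place, a number 7.3 percentage points lower from compound 1 to compound 2 (within the scatter), swapped a chain for a hydroxy there and stayed inside the scatter. A step of a number 3.8 percentage points higher from compound 2 to compound 3 (within the scatter) is therefore expected, nothing beyond the scatter. Compound 3 is estimated at 7%, within -6% to 20%.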

Compound 3, a percentage reported as inhibition, at one concentration (the size of the read-out at that concentration, not a potency): 8.69%
Estimate against measurement, compound 3: 1.7 percentage points below, and the stated range covers the measured number.
By their numbers in this assay, from the lowest: compounds 2, 3 and 1 (each within the scatter of the next).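

Placing 4-hydroxybutyl in place of hydroxy on a saturated chain carbon bound to an aromatic carbon gives a number 5.5 percentage points higher from compound 2 to compound 3 (within the scatter) in this assay. Hydroxy in place of hydrogen on a saturated chain carbon, five bonds along the chain from an aromatic carbon, gives a number 1.8 percentage points lower from compound 1 to compound 3 (within the scatter), so neither the chain nor its hydroxy sets a compound apart here. Nothing available explains these numbers. On these data alone, whether an amine or a carboxylic acid on this chain would move the number beyond the scatter stays open.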